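Phenyl to 3-fluorophenyl on compound 3

This account rests on a few compounds, and the source may have more. Where it says the series, first, only, none or still open, it means among the compounds named here.

Of the compounds shown here, three with different cores have been measured in an ADME assay (liver) for metabolic stability, with Liver microsome (Rattus norvegicus) as the target, using microsomes; a higher number here means faster removal of the compound, a lower number slower removal. Compound 1 (`c1ccc(CNc2nnc(-c3ccc4cnccc4c3)o2)cc1`) gives 166 mL.min-1.g-1, compound 2 (`Nc1n[nH]c2ccc(-c3nnc(NCc4ccccc4)o3)cc12`) gives 74 mL.min-1.g-1 and compound 3 (`c1ccc(CNc2nnc(-c3c[nH]c4ncccc34)o2)cc1`) gives 40 mL.min-1.g-1. Compound 3 stands beyond the scatter below compound 1 and within the scatter of compound 2. Compound 4 (`Fc1cccc(CNc2nnc(-c3c[nH]c4ncccc34)o2)c1`) has fluoro in place of hydrogen on an aromatic carbon of compound 3, meta to a large group (fluoro in place of hydrogen on an aromatic carbon). For the measured compounds named here, no measured pair shows this change, so the expectation has no direct precedent. In this assay, the expected result is no step beyond the scatter, in either direction: an estimated 1.1-fold higher number from compound 3 to compound 4 (0.02 log units; within the scatter). Compound 4 is estimated at 42 mL.min-1.g-1, with an expected range of 20 mL.min-1.g-1 to 85 mL.min-1.g-1.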

Compound 4, intrinsic clearance in microsomes: 71 mL.min-1.g-1
Beside the measured number, compound 4's estimate is 1.7-fold (0.23 log units) below it; measured number inside the range.
By their numbers in this assay, from the lowest: compounds 3, 4 and 2 (each within the scatter of the next); then compound 1.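

In this assay, the series gains its first one-place comparison, with a 1.8-fold higher number from compound 3 to compound 4 (0.25 log units; within the scatter) for phenyl to 3-fluorophenyl. At this position on the benzyl-side ring, fluoro in place of hydrogen therefore gives no step beyond the scatter. No measured evidence bears on this result.

As far as these compounds go, whether methoxy, trifluoromethyl or an amine at this place would also stay within the scatter remains open. So does whether phenyl to 3-fluorophenyl gives a similar step on the cores of compound 1 and compound 2.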